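Methylamino in place of methylsulfanyl: compound 2 to compound 3

The source may hold more compounds than are shown below. What is called first, only, known or untested is meant among the compounds shown, and "the series" means these compounds.

Compound 1 `CN(C)c1nc(N)c2ncn([C@@H]3C[C@@H](O)[C@H](CO)O3)c2n1` and compound 2 `CSc1nc(SC)c2ncn([C@@H]3C[C@@H](O)[C@H](CO)O3)c2n1` carry the shared core with the same sugar-like substituent and differ only in the groups on the six-membered aromatic ring. In a functional assay on HL-60 cells (Homo sapiens) (a lower number here means a stronger inhibitor, a higher number a weaker inhibitor), compound 1 gives > 300 uM, a limit of the assay and not a number. In this assay compound 2 gives > 300 uM, likewise a limit and not a measured number. Both measured values sit at one point: the limit of > 300 uM in this assay, at which 2 of the 2 values shown sit. Compound 2 therefore stands at the edge of what the assay reports, with no numerical potency attached.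

Compound 3 `CNc1nc(SC)nc2c1ncn2[C@@H]1C[C@@H](O)[C@H](CO)O1` is not yet measured. It differs from compound 2 by methylamino in place of methylsulfanyl on an aromatic carbon. Going by the values given here, no step between measured compounds is available to size this change, and nothing measured points in either direction. The expected step of a number no higher from compound 2 to compound 3 (the limit leaves the size open) from compound 2 to compound 3 is none beyond the scatter, most probably another limit. Compound 3 is estimated at 300 uM in this assay, expected to lie between 100 uM and 1000 uM.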

Compound 3, concentration for 50% inhibition: > 300 uM
Compound 3 was reported as a limit; the forecaster's own chance of this, stated with the estimate: 80%; the middle value lies on the limit itself.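

In this assay no size can be read for methylamino in place of methylsulfanyl from compound 2 to compound 3, because both values are limits and not numbers: the limit of > 300 uM in this assay, at which 3 of the 3 values shown sit.

The compounds shown leave open whether any group on the shared core gives a numerical potency in this assay.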